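The source may report more compounds than this note shows. Statements on the series, on what has been measured and on what is new or still open speak of the compounds shown alone.

Measured compounds:
compound 1, `Cc1c(OCCCCOc2cncc(C(=O)O)c2)ccc(C(=O)CC(C)(C)C)c1O`, 490 nM
compound 2, `CNC(=O)c1cc(OCCCCOc2ccc(C(=O)CC(C)(C)C)c(O)c2C)ccc1F`, 164 nM
compound 3, `COc1cc(OCCCCOc2ccc(C(=O)CC(C)(C)C)c(O)c2C)cc(C(=O)O)c1`, 102 nM

All three were tested in an assay for positive allosteric modulation of metabotropic glutamate receptor 2 (Rattus norvegicus); a lower number here means that less compound is needed, a higher number that more compound is needed for the effect. Compound 1 stands at the highest of the three numbers. Its nearest neighbour is compound 2, whose number is lower by an amount beyond the usual scatter; the furthest is compound 3, whose number is lower still, again beyond the scatter. The three compounds share a core and differ only in the aryl group carried on an oxygen on a saturated carbon at the end of the chain.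

Compound 4, `Cc1ccc(C(=O)O)cc1OCCCCOc1ccc(C(=O)CC(C)(C)C)c(O)c1C`, has not yet been measured in this assay. It differs from compound 1 in one place: 5-carboxy-2-methylphenyl in place of 5-carboxypyridin-3-yl on an oxygen on a saturated carbon. Among the measured compounds shown here, no step between two measured compounds matches this exchange, so the expectation rests on the neighbours. Because compound 3 gives 102 nM with a carboxy-bearing carbon-only ring in the same place, compound 4 is expected to move in the same direction, a step of a 3.3-fold lower number from compound 1 to compound 4 (0.51 log units; beyond the scatter) that goes beyond the scatter. Compound 4 is estimated at 150 nM, with a range from 50 nM to 450 nM.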

Compound 4, half-maximal effective concentration: 512 nM
Compound 4: middle estimate off by 3.4-fold (0.53 log units), on the low side; measured number outside the range, above it.
By their numbers in this assay, from the lowest: compounds 3 and 2 (each within the scatter of the next); then compounds 1 and 4 (each within the scatter of the next).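

Putting 5-carboxy-2-methylphenyl in place of 5-carboxypyridin-3-yl on an oxygen on a saturated carbon gives, in this assay, a 1.0-fold higher number from compound 1 to compound 4 (0.02 log units; within the scatter) and so, for this pair, a carbon-only ring does not separate itself from the ring with a nitrogen. Having a carbon-only ring and a carboxylic acid is therefore not enough to reach the number of compound 3 at 102 nM, set against compound 4 at 512 nM with its own substitution on the ring. Nothing shown gives a reason for this result.

This single step swaps the ring nitrogen for carbon and adds a methyl together, so a plain 3-carboxyphenyl group would be needed to read either change alone. As far as these compounds go, it also remains open how an amine or a tetrazole would fare in place of the carboxylic acid on this ring.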